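From propylsulfanyl to benzylamino on the shared core

The compounds below may be only part of what the source reports. "The series", "measured", "known", "first", "only" and "open" are said of these compounds alone.

In an ADME assay on MOLT-3 cells (Homo sapiens) for cytotoxicity, with a stated time of 7 days (a lower number here means that less compound is tolerated, a higher number that more compound is tolerated), compound 1 (`CC(C)CSc1nc(N)nc2c1ncn2/C=C1/CC1(CO)CO`) has the entry "not determined" (no result reported) and offers no guide. Compound 2 (`Nc1nc(OCc2ccccc2)c2ncn(/C=C3/CC3(CO)CO)c2n1`) reads > 20000 nM as a limit and not a number. Compound 3 (`CCCSc1nc(N)nc2c1ncn2/C=C1/CC1(CO)CO`) reads > 20000 nM and that too is only a limit. Together these give the limit of > 20000 nM in this assay, at which 2 of the 3 values shown sit, as the only firm ground. In compound 4 (`Nc1nc(NCc2ccccc2)c2ncn(/C=C3/CC3(CO)CO)c2n1`) benzylamino takes the place of propylsulfanyl on an aromatic carbon (benzylamino in place of propylsulfanyl on an aromatic carbon) of the shared core. Among the compounds with values here, the one measured step is a step that the two limits leave unreadable from compound 2 to compound 3 and it has no readable size, so it sets neither size nor direction. Hence a number no higher from compound 3 to compound 4 (the limit leaves the size open) is expected to stay unreadable too, with no direction foreseen. Compound 4 is estimated at 20000 nM (range 7000 nM to 40000 nM) and may well return only a limit.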

Compound 4, half-maximal cytotoxic concentration: > 20000 nM
Compound 4: only a limit was reported (the forecaster's own chance of this, stated with the estimate: 70%); the middle value sits exactly at the limit.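

Compound 4 gives no readable step against compound 2 or compound 3, because all three report only a limit and not a number: the limit of > 20000 nM in this assay, at which 3 of the 4 values shown sit.

The compounds shown leave open whether benzylamino, benzyloxy and propylsulfanyl differ at all in this assay.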